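Cyclic amidine replaced by an open-chain amide on compound 2

The source may report more compounds than this note shows. Statements on the series, on what has been measured and on what is new or still open speak of the compounds shown alone.

Compound 2 `O=C1CN=C(NC[C@@H]2CCCc3cc(S(=O)(=O)c4cccc(F)c4)ccc32)N1` holds the lowest of the two numbers in an assay on isolated protein for displacement of a labelled ligand from 5-hydroxytryptamine receptor 6 (Homo sapiens) (on this read-out lower numbers stand for stronger inhibition and higher numbers for weaker inhibition), at 0.1 nM. Compound 1 `NC[C@@H]1CCCc2cc(S(=O)(=O)Cc3ccccc3)ccc21` gives 158 nM in this assay; as the two structures differ in more than one place, only their two values can be set side by side. Compound 3 `CN(CC(N)=O)C[C@@H]1CCCc2cc(S(=O)(=O)c3cccc(F)c3)ccc21` is not yet measured; relative to compound 2 the change is a group of 6 heavy atoms (3 carbon, 2 nitrogen, 1 oxygen; no ring) in place of a group of 7 heavy atoms (3 carbon, 3 nitrogen, 1 oxygen; one five-membered non-aromatic ring with 2 hetero atoms), on a saturated chain carbon bound to a saturated ring carbon. Going by the values given here, no measured pair shows this change, so the step from compound 2 to compound 3 in this assay is expected to be a loss, a 100-fold higher number from compound 2 to compound 3 (2.00 log units; beyond the scatter). Compound 3 is estimated at 10 nM in this assay, within 1 nM to 100 nM.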

Compound 3, inhibition constant: 1.26 nM
Beside the measured number, compound 3's estimate is 7.9-fold (0.90 log units) above it, and the stated range covers the measured number.
By their numbers in this assay, from the lowest: compound 2; then compound 3; then compound 1.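

In this assay, placing (carbamoylmethyl)(methyl)amino in place of the five-membered ring group gives a 13-fold higher number from compound 2 to compound 3 (1.10 log units; beyond the scatter) on a saturated chain carbon bound to a saturated ring carbon, so this position responds strongly to this change. Even so, compound 3 at 1.26 nM shows that an open-chain group without that ring can still give a low number here, which the earlier compounds could not show. Nothing available explains the size of this step.

Going by these compounds, whether a carboxylic acid, a primary amine or a longer chain in place of the carbamoylmethyl group would keep such a number remains open. Also open, on these data alone, is whether the methyl on the chain nitrogen contributes to the value of compound 3.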